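The source may hold more compounds than are shown below. What is called first, only, known or untested is meant among the compounds shown, and "the series" means these compounds.

Compound 1 `O=S(=O)(Nc1cccc2cccnc12)c1ccc(F)cc1`: "not determined" (no result reported)
Compound 2 `O=S(=O)(Nc1cccc2cccnc12)c1cnc(Cl)c(Br)c1`: 67400 nM
Compound 3 `CN(C)c1ccc(S(=O)(=O)Nc2cccc3cccnc23)c2ccccc12`: 84200 nM

These entries come from an ADME assay on Vero cells (Homo sapiens) for cytotoxicity against Vero (Chlorocebus sabaeus), read by MTT assay (a lower number here means that less compound is tolerated, a higher number that more compound is tolerated), which shows how much compound cells can take before they are harmed. As far as these compounds go, compound 1 has no number to stand on: its entry reads "not determined" (no result reported), so its place on this scale is unknown. Compound 2 at 67400 nM and compound 3 at 84200 nM lie within the usual scatter of each other, even though their structures differ considerably.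

The next compound to be tested is compound 4 `CCCc1ccc(S(=O)(=O)Nc2cccc3cccnc23)cc1`. The change propyl in place of fluoro on an aromatic carbon puts propyl in place of fluoro on an aromatic carbon, para to a large group. Within the data shown here, no measured pair in this small set shows what such a swap does, and compound 1 offers no starting value. The best available guide is the level shared by the two measured compounds, so no step beyond the scatter, in either direction, is expected from that level in this assay. This is a weak basis, and the range has to stay wide. For compound 4 the estimated value is 65000 nM, with an expected range from 25000 nM to 150000 nM.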

Compound 4, half-maximal cytotoxic concentration: 64400 nM
Beside the measured number, compound 4's estimate is 1.0-fold (0.00 log units) above it; the range from low to high includes it.
By their numbers in this assay, from the lowest: compounds 4, 2 and 3 (each within the scatter of the next).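

Among these compounds, the entry for compound 1 in this assay reads "not determined" (no result reported), so no step from it to compound 4 can be read. Nothing in the data explains the level of compound 4. The compounds shown leave open how putting propyl in place of fluoro changes the amount of compound that cells tolerate.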